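Removing the nitro group from a dienone series

The source may report more compounds than this note shows. Statements on the series, on what has been measured and on what is new or still open speak of the compounds shown alone.

Three compounds share a core in which two double-bonded chains meet at a carbonyl. Compound 1 `O=C(/C=C/c1ccc(Oc2ncnc3ccc(Cl)cc23)cc1)/C=C/c1cc([N+](=O)[O-])ccc1Cl` and compound 2 `O=C(/C=C/c1ccc(Oc2ncnc3ccc(Cl)cc23)cc1)/C=C/c1ccc(Cl)c([N+](=O)[O-])c1` differ only in the ring at one chain end, and in a functional assay on MGC-803 cells (Homo sapiens) for inhibition, read by MTT assay, with a stated time of 72 h, tested at 10 uM (a higher number here means more inhibition of growth at the concentration tested, a lower number less inhibition of growth), compound 1 gives 86.7% while compound 2 gives 66.2%, a change of a number 20.5 percentage points lower from compound 1 to compound 2 (beyond the scatter). Compound 3 `O=C(/C=C/c1cc([N+](=O)[O-])ccc1Cl)/C=C/c1ccccc1Oc1ncnc2ccc(Cl)cc12` gives 91.6% in this assay, the highest of the three numbers, though its gap to compound 1 lies within the scatter and only its gap to compound 2 lies beyond it.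

Compound 4 `O=C(/C=C/c1ccccc1Oc1ncnc2ccc(Cl)cc12)/C=C/c1c(Cl)cccc1Cl` differs from compound 3 by one change: 2,6-dichlorophenyl in place of 2-chloro-5-nitrophenyl on a double-bonded chain carbon bound to a double-bonded chain carbon. Among the compounds with values here, no measured step removes the nitro group, so the only guide is the step from compound 1 to compound 2, which changed the substituents on this same ring and moved the number modestly. A step of comparable size is expected here, more likely downward than upward, giving an estimated change of a number 16.6 percentage points lower from compound 3 to compound 4 (beyond the scatter). Compound 4 is therefore expected to reach about 75% in this assay, within a range from 52% to 92%.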

Compound 4, percent growth inhibition at one concentration: 69.3%
For compound 4 the middle estimate is 5.7 percentage points above the measured one, within the range that was stated.
By their numbers in this assay, from the lowest: compounds 2 and 4 (each within the scatter of the next); then compounds 1 and 3 (each within the scatter of the next).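

Replacing 2-chloro-5-nitrophenyl with 2,6-dichlorophenyl on a double-bonded chain carbon bound to a double-bonded chain carbon gives a number 22.3 percentage points lower from compound 3 to compound 4 (beyond the scatter) in this assay. This is the first step shown in which the nitro group leaves altogether, and it shows that the number at this position can fall beyond the scatter with that change. However, the entering group also brings a second chlorine, so this one step cannot separate the loss of the nitro group from the gain of chlorine, and nothing measured here explains the drop.

As far as these compounds go, whether an amine or a carboxylic acid in place of the nitro group would keep the number up remains open. So does whether 2,6-dichlorophenyl would have a similar effect on the core of compound 1.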